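Compound 3: piperidin-1-yl in place of (3-fluorophenyl)amino

The compounds below may be only part of what the source reports. "The series", "measured", "known", "first", "only" and "open" are said of these compounds alone.

Going by the values given here, compound 2 `O=C1C=C(Nc2cccc(F)c2)C(=O)c2c1nc1n2[C@H]2OC[C@@H](O)[C@H]2OC1` carries the only numerical value in this set: in a functional assay on ECa-109 cells for inhibition, with ECa-109 cell line (Homo sapiens) as the target, read by sulforhodamine B assay (a higher number here means a weaker inhibitor, a lower number a stronger inhibitor), compound 2 gives 7030 nM. Compound 1 `CCCc1ccc(NC2=CC(=O)c3nc4n(c3C2=O)[C@H]2OC[C@@H](O)[C@H]2OC4)cc1` reaches only a limit of the assay; in this assay compound 1 gives > 4000 nM, a limit and not a number. The step that the limit leaves unreadable from compound 1 to compound 2 cannot be sized, as the limit of > 4000 nM in this assay, at which 1 of the 2 values shown sits, makes clear. Compound 3 `O=C1C=C(N2CCCCC2)C(=O)c2c1nc1n2[C@H]2OC[C@@H](O)[C@H]2OC1` differs from compound 2 by piperidin-1-yl in place of (3-fluorophenyl)amino on a double-bonded ring carbon. Among the compounds with values here, no measured step bears on this change: the single step in the set is unreadable, and neither compound touches a six-membered non-aromatic ring with 1 hetero atom at this position. No shift beyond the scatter can be expected in either direction, so the estimate rests on compound 2 alone. Compound 3 is expected to give 7000 nM, between 2000 nM and 25000 nM, an expected step of a 1.0-fold lower number from compound 2 to compound 3 (0.00 log units; within the scatter). A further limit instead of a number remains a real possibility.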

Compound 3, half-maximal inhibitory concentration: > 8000 nM
Compound 3 gave a limit, no number; the forecaster's own chance of this, stated with the estimate: 30%; at least 1.1-fold (0.05 log units) between middle value and limit.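

In this assay, going by these compounds alone, piperidin-1-yl in place of (3-fluorophenyl)amino on the double-bonded ring carbon gives an at least 1.1-fold higher number from compound 2 to compound 3 (0.05 log units; that floor lies within the scatter), the only step that can be read at all, and only as a floor. Compound 3 gives a limit and not a number, so the full size of this step cannot be read: the limit of > 8000 nM in this assay, at which 1 of the 3 values shown sits. Even so, this position has now been probed with a group lacking both a hydrogen-bond donor and an aromatic ring, and compound 3 gives no sign of stronger inhibition.

This change removes the donor and the aromatic ring together, and the compounds shown do not separate the two. A cyclohexylamino group, which keeps the amine hydrogen without the aromatic ring, would bear directly on that question.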